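From Ethoxymethyl to Isopropoxymethyl on a Shared Core

The source may hold more compounds than are shown below. What is called first, only, known or untested is meant among the compounds shown, and "the series" means these compounds.

Of the compounds shown here, three sharing a core have been measured in a functional assay on MES-SA cells (Homo sapiens) for inhibition, with a stated time of 72 h; on this read-out higher numbers stand for weaker inhibition and lower numbers for stronger inhibition. In this assay compound 1 `CC(C)OCc1cc(CN2CCCCC2)c(O)c2ncccc12` gives 6030 nM. Compound 2 `CC1CCN(Cc2cc(Cl)c3cccnc3c2O)CC1` gives 2700 nM; 2690 nM (2 entries), and its repeat entries agree closely: the several entries of compound 2 in this assay, 2700 nM; 2690 nM (2 entries). Compound 3 `CCOCc1cc(CN2CCC(C)CC2)c(O)c2ncccc12` gives 4070 nM, a number within the scatter of that of compound 1, so the two cannot be ranked.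

Compound 4 `CC1CCN(Cc2cc(COC(C)C)c3cccnc3c2O)CC1` has not yet been measured. It departs from compound 3 by a single change methyl in place of hydrogen on a saturated chain carbon bound to an oxygen on a saturated carbon and a saturated chain carbon: methyl in place of hydrogen on a saturated chain carbon bound to an oxygen, which turns ethoxymethyl into isopropoxymethyl. Within the data shown here, no direct step of this kind has been measured. The nearest guide is compound 1, which also carries isopropoxymethyl and gives 6030 nM, within the scatter of compound 3. No change beyond the scatter is therefore expected in this assay, and the estimated step of a 1.0-fold lower number from compound 3 to compound 4 (0.01 log units; within the scatter) is expected to be small. For compound 4 the expected value is 4000 nM, with an estimated range of 2000 nM to 8000 nM.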

Compound 4, half-maximal inhibitory concentration: 2820 nM
Compound 4: the middle estimate sits 1.4-fold (0.15 log units) above what was measured, and the stated range covers the measured number.
By their numbers in this assay, from the lowest: compounds 4, 3 and 1 (each within the scatter of the next, the first and the last beyond it).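

Read directly in this assay, the change from ethoxymethyl to isopropoxymethyl gives a 1.4-fold lower number from compound 3 to compound 4 (0.16 log units; within the scatter) and so cannot be told apart from the scatter at this saturated chain carbon bound to an oxygen. With isopropoxymethyl held constant, methyl in place of hydrogen on a saturated ring carbon gives a 2.1-fold lower number from compound 1 to compound 4 (0.33 log units; beyond the scatter) as a modest step, the only one of the two new steps beyond the scatter. Repeat readings in this assay can lie close together, as they do here: the several entries of compound 2 in this assay, 2700 nM; 2690 nM (2 entries)

The compounds shown leave open how a longer chain such as butoxymethyl, or an amine or a carboxylic acid in place of the ether, would read at this position. They also leave open whether methyl on the saturated ring carbon would give a similar step with ethoxymethyl in place of isopropoxymethyl.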